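The source may hold more compounds than are shown below. What is called first, only, known or untested is meant among the compounds shown, and "the series" means these compounds.

Three compounds of the series have numbers in an assay on membranes from brain for displacement of a labelled ligand from Sigma non-opioid intracellular receptor 1 (Cavia porcellus); a higher number here means a weaker inhibitor, a lower number a stronger inhibitor. Compound 1 `O=C(CCCc1ccccc1)OC(CCN1CCN(CCCN(c2ccc(F)cc2)c2ccc(F)cc2)CC1)c1ccccc1` gives 246 nM. Compound 2 `CC(=O)OC(CCN1CCN(CCCN(c2ccc(F)cc2)c2ccc(F)cc2)CC1)c1ccccc1` gives 56.6 nM. Compound 3 `C=CC(=O)OC(CCN1CCN(CCCN(c2ccc(F)cc2)c2ccc(F)cc2)CC1)c1ccccc1` gives 87.3 nM. Compound 3 thus stands second highest of the three numbers; its nearest neighbour is compound 2, with the step of a 1.5-fold higher number from compound 2 to compound 3 (0.19 log units; within the scatter) staying within the scatter, while the step of a 2.8-fold lower number from compound 1 to compound 3 (0.45 log units; beyond the scatter) lies beyond it. The step of a 4.3-fold lower number from compound 1 to compound 2 (0.64 log units; beyond the scatter) is the largest shown so far.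

Compound 4 `CCC(=O)OC(CCN1CCN(CCCN(c2ccc(F)cc2)c2ccc(F)cc2)CC1)c1ccccc1` is not yet measured. It differs from compound 3 by ethyl in place of vinyl on a carbonyl carbon. Going by the values given here, of the measured steps, only one concerns a change of small groups at the same carbonyl carbon: a 1.5-fold higher number from compound 2 to compound 3 (0.19 log units; within the scatter), which stayed within the scatter. The steps from compound 1 involve a much larger group leaving and offer little guidance for this change. For compound 4 the number in this assay is therefore expected to sit close to that of compound 3, with no step beyond the scatter in either direction; the expected step is a 1.2-fold lower number from compound 3 to compound 4 (0.07 log units; within the scatter). The estimate for compound 4 is 75 nM, with a range from 35 nM to 160 nM.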

Compound 4, inhibition constant: 76 nM
The estimate for compound 4 lay 1.0-fold (0.01 log units) below the measured number, and the stated range covers the measured number.
By their numbers in this assay, from the lowest: compounds 2, 4 and 3 (each within the scatter of the next); then compound 1.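

In this assay the ethyl-for-vinyl change on a carbonyl carbon stays within the scatter (a 1.1-fold lower number from compound 3 to compound 4 (0.06 log units; within the scatter)), and so does methyl in place of hydrogen on a saturated chain carbon bound to a carbonyl carbon (a 1.3-fold higher number from compound 2 to compound 4 (0.13 log units; within the scatter)), so at this position neither the double bond outside aromatic rings nor this one-carbon extension gives a readable change, and compounds 2, 3 and 4 now form a set within the scatter of one another. Compound 1 remains the only one apart, and the step to the propanoyl ester compound 4 (a 3.2-fold lower number from compound 1 to compound 4 (0.51 log units; beyond the scatter)) lies beyond the scatter, as do the steps from compound 1 to the other two small esters, so the series separates only when the large group with its terminal phenyl ring is present. The data at hand offer no explanation for any of these steps.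

The compounds shown leave open where between propanoyl and the long acyl group of compound 1 the number starts to rise, which a butanoyl or pentanoyl chain would address, and whether that rise needs the terminal phenyl ring at all. They also leave open whether the ester link itself matters, which an amide or a free hydroxyl at this position would test.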